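Carbamoyl to Tetrazolyl: an Expected Outcome for Compound 4

A few compounds are considered here, and "the series" means these few. Any claim that something is new, unique, unknown or untested is made for them only; others in the source may bear on it.

Measured so far:
Compound 1, `CCCCS(=O)(=O)NNC(=O)[C@@H](NC(=O)c1cccc(Cn2ccnc2)c1)[C@@H](C)CC`: "not determined" (no result reported)
Compound 2, `CC[C@H](C)[C@H](NC(=O)c1cccc(Cn2ccnc2)c1)C(N)=O`: "not active" (no number reported)
Compound 3, `CC[C@H](C)[C@H](NC(=O)c1cccc(Cn2ccnc2)c1)C(=O)NNS(=O)(=O)c1ccc(C)cc1`: 4%

All three share one core and were tested in an assay on HEK293 cells for displacement of a labelled ligand from Type-2 angiotensin II receptor (Homo sapiens), tested at 1 uM; a lower number here means a weaker effect, a higher number a stronger effect of the compound at the concentration tested. Compound 1 has no result there, reported as "not determined" (no result reported). Compound 2 stands without a single number, reported only as "not active" (no number reported), and it is one of two entries here without a number. Compound 3 is the only one with a figure, and in this assay compound 3 gives 4%, a weak effect.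

The new compound 4, `CC[C@H](C)[C@H](NC(=O)c1cccc(Cn2ccnc2)c1)c1nn[nH]n1`, differs from compound 2 in one place: 2H-tetrazol-5-yl in place of carbamoyl on a saturated chain carbon bound to an amide-type nitrogen and a saturated chain carbon. For the measured compounds named here, no measured pair shows what such a change does in this assay, so only a small step, if any, is expected, in no firm direction. Compound 4 is estimated to give 8%, with a range from 0% to 25%.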

Compound 4, a percentage reported as inhibition, at one concentration (the size of the read-out at that concentration, not a potency): "not active" (no number reported)
No number was reported for compound 4, and the estimate cannot be compared.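

Neither compound 2 nor compound 4 carries a number, and no step can be read between them. Nothing available bears on this result. From the compounds shown here alone, whether carbamoyl or 2H-tetrazol-5-yl gives the larger effect stays open.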